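Moving a Bromine Around the Benzyl Ring

A few compounds are considered here, and "the series" means these few. Any claim that something is new, unique, unknown or untested is made for them only; others in the source may bear on it.

Of the compounds shown here, three built on one shared core have been measured in an assay on PC-12 cells for displacement of a labelled ligand from vesicular acetylcholine transporter (Homo sapiens); on this read-out higher numbers stand for weaker inhibition and lower numbers for stronger inhibition. Compound 1 `OC1CNCCC1N1CCN(c2ccccc2)CC1` carries a hydrogen on the amine nitrogen in the ring, and in this assay compound 1 gives 100 nM. Compound 2 `OC1CN(Cc2ccccc2)CCC1N1CCN(c2ccccc2)CC1` carries a benzyl in that place, and compound 2 gives 57 nM, so that a 1.8-fold lower number from compound 1 to compound 2 (0.24 log units; within the scatter). Compound 3 `OC1CN(Cc2cccc(Br)c2)CCC1N1CCN(c2ccccc2)CC1` carries a 3-bromobenzyl there, and compound 3 gives 66 nM. That is the second highest of the three numbers, yet a 1.5-fold lower number from compound 1 to compound 3 (0.18 log units; within the scatter) and a 1.2-fold higher number from compound 2 to compound 3 (0.06 log units; within the scatter), so all three values sit within the usual scatter of one another.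

Compound 4 `OC1CN(Cc2ccc(Br)cc2)CCC1N1CCN(c2ccccc2)CC1` differs from compound 3 in a single place: 4-bromophenyl in place of 3-bromophenyl on a saturated chain carbon bound to an amine nitrogen in a ring. For the measured compounds named here, no measured step moves the bromine itself from one spot on the ring to another. The nearest guidance comes from putting the bromine on at all, where a 1.2-fold higher number from compound 2 to compound 3 (0.06 log units; within the scatter), and from the two substitutions on the amine nitrogen, a 1.8-fold lower number from compound 1 to compound 2 (0.24 log units; within the scatter) and a 1.5-fold lower number from compound 1 to compound 3 (0.18 log units; within the scatter), none of which left the scatter. The expected outcome is therefore no step beyond the scatter: no change at the digits printed from compound 3 to compound 4 (within the scatter). Compound 4 is estimated at 66 nM, with a range from 33 nM to 130 nM.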

Compound 4, half-maximal inhibitory concentration: > 100 nM
Compound 4: only a limit was reported; the forecaster's own chance of this, stated with the estimate: 0%; at least 1.5-fold (0.18 log units) between middle value and limit.
By their numbers in this assay, from the lowest: compounds 2, 3 and 1 (each within the scatter of the next).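

In this assay compound 4 gives > 100 nM, which is a limit of the assay and not a number: the limit of > 100 nM in this assay, at which 1 of the 4 values shown sits. Moving the bromine, with the same atoms joined differently, gives an at least 1.5-fold higher number from compound 3 to compound 4 (0.18 log units; that floor lies within the scatter), and bromo in place of hydrogen at this new spot gives an at least 1.7-fold higher number from compound 2 to compound 4 (0.24 log units; that floor lies within the scatter); both are floors that lie within the scatter, while the true size of each step stays unknown and may be larger. For the compounds shown here, every earlier step had a readable size within the scatter, so the change from 3-bromobenzyl to 4-bromobenzyl is the first here that could reach beyond it, though the floor does not show that it does, and 4-bromobenzyl in place of hydrogen on the amine nitrogen in the ring gives a number no lower from compound 1 to compound 4 (the limit leaves the size open), a step that cannot be read.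

On these data alone, how far the true number for compound 4 lies from its limit stays open, and with it how much the bromine's place on the benzyl ring matters. Also open, as far as these compounds go, is whether a 4-chlorobenzyl or a 4-methoxybenzyl in place of the 4-bromobenzyl would read like compound 3 or like compound 4.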